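The source may report more compounds than this note shows. Statements on the series, on what has been measured and on what is new or still open speak of the compounds shown alone.

Compound 3 `COc1cc2oc(=O)n(CCC(=O)O)c2cc1Cl` stands at a limit in a physicochemical assay for permeability, using PAMPA; a higher number here means that the compound crosses the layer faster, a lower number that the compound crosses the layer more slowly: compound 3 gives < 3 nm/s, which is a limit of the assay and not a number. The other two compounds share the same core. Compound 1 `CCc1cc2oc(=O)n(CCC(=O)O)c2cc1Cl` gives < 10 nm/s in this assay, also a limit. Compound 2 `O=C(O)CCn1c(=O)oc2cc(OCC3CC3)c(Cl)cc21` gives 19 nm/s in this assay. Compound 4 `O=C(O)CCn1c(=O)oc2cc(OCC3CCC3)c(Cl)cc21` differs from compound 3 by cyclobutyl in place of hydrogen on a saturated chain carbon bound to an oxygen on an aromatic ring. The measured step that bears on this runs the other way: an at least 6.3-fold lower number from compound 2 to compound 3 (0.80 log units; beyond the scatter). The steps of an at least 1.9-fold higher number from compound 1 to compound 2 (0.27 log units; that floor lies within the scatter) and a step that the two limits leave unreadable from compound 1 to compound 3 add little, the second being unreadable. Cyclobutyl in place of hydrogen should reverse that loss and carry compound 4 to a number close to compound 2. The step of an at least 8.3-fold higher number from compound 3 to compound 4 (0.92 log units; beyond the scatter) is therefore expected. Compound 4 is estimated at 25 nm/s, within 10 nm/s to 60 nm/s.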

Compound 4, apparent permeability: 12 nm/s
Compound 4: middle estimate off by 2.1-fold (0.32 log units), on the high side; the range from low to high includes it.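

In this assay, cyclobutyl at this place, on a saturated chain carbon bound to an oxygen on an aromatic ring, gives a second ring-bearing compound clear of the methoxy compound: an at least 4.0-fold higher number from compound 3 to compound 4 (0.60 log units; beyond the scatter). Between the two rings the data separate nothing, a 1.6-fold lower number from compound 2 to compound 4 (0.20 log units; within the scatter), and the comparison with ethyl on an aromatic carbon adds only a weak floor, an at least 1.2-fold higher number from compound 1 to compound 4 (0.07 log units; that floor lies within the scatter). Compound 3 stands at a limit and not a number, so the gain over it has a floor but no size: the limit of < 3 nm/s in this assay, at which 1 of the 4 values shown sits.

Open, on these data alone, is how cyclopentyl or an open butyl chain would read at this place. Also open, as far as these compounds go, is whether an amine on the same chain would hold the number of compound 4.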